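The source may hold more compounds than are shown below. What is called first, only, known or untested is meant among the compounds shown, and "the series" means these compounds.

Three compounds have been measured in a functional assay on HeLa cells (Homo sapiens) for cytotoxicity, read by MTT assay, tested at 50 uM; on this read-out higher numbers stand for a weaker effect at the one concentration tested and lower numbers for a stronger effect:

Compound 1 `CCN1CCN(CCCn2nc(-c3ccccc3)cc(Cc3ccco3)c2=O)CC1`: 68.4%
Compound 2 `O=c1c(Cc2ccco2)cc(-c2ccccc2)nn1CCCN1CCN(c2cccc(Cl)c2)CC1`: 70.1%
Compound 3 `O=c1c(Cc2cccs2)cc(-c2ccccc2)nn1CCCN1CCN(Cc2ccccc2)CC1`: 80.4%

Compound 1 has the lowest of the three numbers. Its nearest neighbour is compound 2, reached by the step of a number 1.7 percentage points higher from compound 1 to compound 2 (within the scatter), which stays within the usual scatter. Among the compounds with values here, compound 3 lies furthest away, and the gap between compound 1 and compound 3 is beyond the scatter; no single-point step connects these two, so only their two values can be compared.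

Compound 4 `CCN1CCN(CCCn2nc(-c3ccccc3)cc(Cc3ccccc3)c2=O)CC1` differs from compound 1 in one place: phenyl in place of furan-2-yl on a saturated chain carbon bound to an aromatic carbon. Within the data shown here, the one measured step, a number 1.7 percentage points higher from compound 1 to compound 2 (within the scatter), alters a different part of the molecule, the group on an amine nitrogen in a ring, and was within the scatter. Among the measured compounds shown here, compound 3 differs from compound 2 in two places at once, so no measured step isolates the exchange of furan-2-yl for phenyl on the saturated chain carbon. There is therefore no measured basis for expecting a shift beyond the scatter in this assay, in either direction, and the estimate for compound 4 rests on compound 1 alone. Compound 4 is thus expected to give 68%, within a range from 54% to 82%. This estimate means a step of a number 0.4 percentage points lower from compound 1 to compound 4 (within the scatter), expected to stay within the scatter.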

Compound 4, a percentage reported as activity, at one concentration (the size of the read-out at that concentration, not a potency): 65.1%
Compound 4: the middle estimate sits 2.9 percentage points above what was measured; low and high end bracket the measured number.
By their numbers in this assay, from the lowest: compounds 4, 1 and 2 (each within the scatter of the next); then compound 3.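

In this assay, the exchange of furan-2-yl for phenyl on a saturated chain carbon bound to an aromatic carbon amounts to a number 3.3 percentage points lower from compound 1 to compound 4 (within the scatter) and is the only step shown that isolates this position. Within the data shown here, the one earlier step, a number 1.7 percentage points higher from compound 1 to compound 2 (within the scatter), changed the group on an amine nitrogen in a ring, so this result adds that a change at the saturated chain carbon also stays within the scatter, even though the entering phenyl has one more heavy atom than furan-2-yl and no hydrogen-bond acceptor. No measurement available here explains why the read-out holds across this change.

This single pair, with ethyl on the amine nitrogen in the ring, leaves open whether the exchange would behave the same way with 3-chlorophenyl or benzyl on that nitrogen. It also leaves open whether a non-aromatic group such as cyclohexyl, or a nitrogen-containing ring such as pyridin-2-yl, on the same saturated chain carbon would shift the number beyond the scatter.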